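From a difluorobenzyl amide to an ethoxyphenyl amide

A few compounds are considered here, and "the series" means these few. Any claim that something is new, unique, unknown or untested is made for them only; others in the source may bear on it.

Of the compounds shown here, three have been measured in a functional assay on A549 cells (Homo sapiens) for inhibition, read by MTT assay, with a stated time of 48 h; on this read-out lower numbers stand for stronger inhibition and higher numbers for weaker inhibition. Compound 1 `COc1ccc2c(=O)c(/C=C/C(=O)NCc3ccccc3)coc2c1` gives 11800 nM. Compound 2 `COc1ccc(NC(=O)/C=C/c2coc3cc(OC)ccc3c2=O)cc1` gives 23000 nM. Compound 3 `COc1ccc2c(=O)c(/C=C/C(=O)NCc3ccc(F)cc3F)coc2c1` gives 13300 nM.

On these numbers compound 3 stands second highest of the three. Its nearest neighbour is compound 1, the step being a 1.1-fold higher number from compound 1 to compound 3 (0.05 log units; within the scatter); its furthest is compound 2, with a 1.7-fold lower number from compound 2 to compound 3 (0.24 log units; within the scatter). All three values thus lie within the scatter of one another, and no order among them can be claimed.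

Compound 4 `CCOc1ccc(NC(=O)/C=C/c2coc3cc(OC)ccc3c2=O)cc1` differs from compound 3 in one place: 4-ethoxyphenyl in place of 2,4-difluorobenzyl on an amide-type nitrogen. Among the compounds with values here, two measured steps bear on this. The step of a 1.9-fold higher number from compound 1 to compound 2 (0.29 log units; within the scatter) exchanges a benzyl for an alkoxy-substituted phenyl on the amide-type nitrogen, and the step of a 1.7-fold lower number from compound 2 to compound 3 (0.24 log units; within the scatter) goes the other way, from such a phenyl back to a benzyl. Both are within the scatter. Compound 4 carries an alkoxyphenyl directly on the amide-type nitrogen, as compound 2 does, and the ethoxy group differs from the methoxy of compound 2 only by one carbon. The expected step of a 1.5-fold higher number from compound 3 to compound 4 (0.18 log units; within the scatter) is therefore small, leaning toward a higher number, but not clearly beyond the scatter. Compound 4 is estimated in this assay at 20000 nM, within a range from 9000 nM to 45000 nM.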

Compound 4, half-maximal inhibitory concentration: > 100000 nM
Compound 4: a limit, no number (the forecaster's own chance of this, stated with the estimate: 10%); middle value at least 5.0-fold (0.69 log units) from the limit.
By their numbers in this assay, from the lowest: compounds 1, 3 and 2 (each within the scatter of the next). At a limit, above all of these: compound 4.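

In this assay compound 4 stands at a limit of the assay and has no number: the limit of > 100000 nM in this assay, at which 1 of the 4 values shown sits.

Within the data shown here, this yields the first steps beyond the scatter: exchanges on the amide-type nitrogen, which among the three earlier compounds stayed within the scatter, now give an at least 7.5-fold higher number from compound 3 to compound 4 (0.87 log units; beyond the scatter) and an at least 8.4-fold higher number from compound 1 to compound 4 (0.92 log units; beyond the scatter). The smallest change of the three matters most, for methyl in place of hydrogen on a saturated chain carbon bound to an oxygen on an aromatic ring, which turns the methoxy into the ethoxy, gives an at least 4.3-fold higher number from compound 2 to compound 4 (0.63 log units; beyond the scatter), so a phenyl set directly on the amide-type nitrogen does not alone decide the read-out, and the terminal carbon of the alkoxy chain counts as well.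

From the compounds shown here alone, all three steps end at a limit, so how far the true value of compound 4 lies past it stays open, and they fix only a smallest possible size. The compounds shown also leave open whether a longer chain such as propoxy in that place would read as the ethoxy does, or whether a hydroxy group there would read as the methoxy does.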